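Toxicity notes: oxan-4-yl in place of pyridin-3-yl

The compounds below may be only part of what the source reports. "The series", "measured", "known", "first", "only" and "open" are said of these compounds alone.

Three compounds have been run in a toxicity assay on THP-1 cells (Homo sapiens) for inhibition (on this read-out lower numbers stand for higher toxicity in this test and higher numbers for lower toxicity in this test), and each gives only a limit. Compound 1 `COc1ccc(CNC(=O)NC(=O)c2ccc(F)cc2)cc1` gives > 50000 nM, a limit. Compound 3 `Cn1c(-c2ccccc2)cnc1NC(=O)c1cc(-c2ccccn2)[nH]n1` gives > 50000 nM, again a limit. Compound 2 `COc1ccc(-c2cnc(NC(=O)c3cccnc3)n2C)cc1` gives > 100000 nM, also a limit, so on the numbers shown compound 2 sits at the limit of > 100000 nM in this assay, at which 1 of the 3 values shown sits. The other two sit at the limit of > 50000 nM in this assay, at which 2 of the 3 values shown sit. Among the measured compounds shown here, no pair of these differs in one place, so no measured step exists. Compound 4 `COc1ccc(-c2cnc(NC(=O)C3CCOCC3)n2C)cc1` differs from compound 2 by oxan-4-yl in place of pyridin-3-yl on a carbonyl carbon. With all three measured compounds at limits, the step from compound 2 to compound 4 is expected to be a number no higher from compound 2 to compound 4 (the limit leaves the size open), none beyond the scatter. Compound 4 is therefore estimated at 100000 nM, within 50000 nM to 200000 nM, most likely reported again only as a limit in this assay.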

Compound 4, half-maximal cytotoxic concentration: > 100000 nM
Compound 4: a limit, no number (the forecaster's own chance of this, stated with the estimate: 85%); the middle value lies on the limit itself.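

Compound 2 gives > 100000 nM, a limit. Compound 4 gives > 100000 nM, also a limit, so no step can be read between these two compounds. As far as these compounds go, whether oxan-4-yl in place of pyridin-3-yl changes anything in this assay stays open.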